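The source may report more compounds than this note shows. Statements on the series, on what has been measured and on what is new or still open speak of the compounds shown alone.

Measured so far:
compound 1 `CC(C)(C)CCOc1cccc(O)c1C(=O)/C=C/c1ccc(C(=O)O)cc1`: 2170 nM
compound 2 `CC(C)(C)CCOc1cccc(O)c1C(=O)/C=C/c1ccc(O)cc1`: 3430 nM

Within the data shown here, in a functional assay on HCT-15 cells (Homo sapiens) for antiproliferative activity, read by sulforhodamine B assay (a lower number here means a stronger inhibitor of growth, a higher number a weaker inhibitor of growth), compound 2 stands level with compound 1, the only other measured compound. The next structure is compound 3 `CC(C)(C)CCOc1cccc(O)c1C(=O)/C=C/c1ccc(S(N)(=O)=O)cc1`, with sulfamoyl in place of hydroxy on an aromatic carbon. Among the measured compounds shown here, one measured step bears on this position, the exchange of carboxy for hydroxy: a 1.6-fold higher number from compound 1 to compound 2 (0.20 log units; within the scatter). For the measured compounds named here, with only that small step as a guide, no change beyond the scatter is expected in this assay. The expected step is a 1.2-fold lower number from compound 2 to compound 3 (0.09 log units; within the scatter). Compound 3 is estimated at 2800 nM, with an expected range of 1200 nM to 6500 nM.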

Compound 3, concentration for 50% growth inhibition: 2930 nM
Beside the measured number, compound 3's estimate is 1.0-fold (0.02 log units) below it, and the stated range covers the measured number.
By their numbers in this assay, from the lowest: compounds 1, 3 and 2 (each within the scatter of the next).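

In this assay, sulfamoyl joins carboxy and hydroxy at this position, with exchange for hydroxy giving a 1.2-fold lower number from compound 2 to compound 3 (0.07 log units; within the scatter) and exchange for carboxy giving a 1.4-fold higher number from compound 1 to compound 3 (0.13 log units; within the scatter). Both steps lie within the scatter, so the larger sulfamoyl, with its 4 heavy atoms, does not separate from either earlier group in this assay. No evidence is available on why the three compounds stand level.

As far as these compounds go, whether an amine or a fluorine at this position would move the number beyond the scatter remains open. So does the effect of changes elsewhere on the shared core.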